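Changing the Sulfonyl Substituent from Compound 3 to Compound 4

The source may report more compounds than this note shows. Statements on the series, on what has been measured and on what is new or still open speak of the compounds shown alone.

Of the compounds shown here, three sharing one core have been measured in a physicochemical assay for solubility, in phosphate buffer, with a stated time of 24 h, at pH 7.4, tested at 100 uM (on this read-out lower numbers stand for lower solubility and higher numbers for higher solubility), and they differ only in the group on the sulfonyl sulfur. Compound 1 `O=C(NCc1ccc(S(=O)(=O)c2cncc(C(F)(F)F)c2)cc1)N1Cc2ccncc2C1`, which carries 5-(trifluoromethyl)pyridin-3-yl, gives 83000 nM. Compound 2 `CC(C)n1cc(S(=O)(=O)c2ccc(CNC(=O)N3Cc4ccncc4C3)cc2)cn1`, which carries 1-isopropyl-1H-pyrazol-4-yl, gives 192000 nM. Compound 3 `CCC(=O)N1CCC(S(=O)(=O)c2ccc(CNC(=O)N3Cc4ccncc4C3)cc2)CC1`, which carries 1-propanoylpiperidin-4-yl, gives 216000 nM. This places compound 3 level with compound 2 within the scatter and clear of compound 1.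

The three measured steps all bear on the next change, since all occur at this same place. Two are modest, a 2.3-fold higher number from compound 1 to compound 2 (0.36 log units; beyond the scatter) and a 2.6-fold higher number from compound 1 to compound 3 (0.42 log units; beyond the scatter), while the third is a 1.1-fold higher number from compound 2 to compound 3 (0.05 log units; within the scatter).

Compound 4 `O=C(NCc1ccc(S(=O)(=O)N2CCOCC2)cc1)N1Cc2ccncc2C1` differs from compound 3 as follows: morpholin-4-yl in place of 1-propanoylpiperidin-4-yl on a sulfonyl sulfur. The new group sits on a sulfonyl sulfur whose other neighbour is an aromatic carbon, as before. Going by the values given here, no measured compound carries morpholin-4-yl, so the expectation rests on these steps alone. None of them exceeds a modest size, and compound 4 does not bring back the group of compound 1. The expected change is a 1.1-fold lower number from compound 3 to compound 4 (0.06 log units; within the scatter), which would be no step beyond the scatter. Compound 4 is estimated at 190000 nM, with an expected range from 110000 nM to 300000 nM.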

Compound 4, solubility: 59000 nM
For compound 4 the middle estimate is 3.2-fold (0.51 log units) above the measured one; the measured number lies below the stated range.
By their numbers in this assay, from the lowest: compounds 4 and 1 (each within the scatter of the next); then compounds 2 and 3 (each within the scatter of the next).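

Moving to morpholin-4-yl gives the first large-side result among the non-aromatic groups at this sulfonyl sulfur: in this assay there is a 3.7-fold lower number from compound 3 to compound 4 (0.56 log units; beyond the scatter) for the change itself and a 3.3-fold lower number from compound 2 to compound 4 (0.51 log units; beyond the scatter) against the pyrazole-bearing compound, so the two earlier high values do not extend to every group placed here. The result also breaks any division by ring type, since a 1.4-fold lower number from compound 1 to compound 4 (0.15 log units; within the scatter) sets compound 4 level with the 5-(trifluoromethyl)pyridin-3-yl compound, leaving one aromatic and one non-aromatic ring in each of the lower and upper pairs. The change from 1-propanoylpiperidin-4-yl also goes from 10 heavy atoms to 6 and loses the double bond outside aromatic rings, while the count of hydrogen-bond acceptors stays the same, so those counts alone do not settle which difference matters.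

A 4-propanoylpiperazin-1-yl group on the same sulfur, or a piperidin-4-yl ring without the propanoyl chain, would help separate the effect of ring atoms from that of the chain. Nothing among the data shown explains why compound 4 sits where it does.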